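This account rests on a few compounds, and the source may have more. Where it says the series, first, only, none or still open, it means among the compounds named here.

Compound 1 `CC(=O)OC[C@H]1[C@H]2CC[C@@H](C)[C@]1(C)CC/C(C)=C/CC[C@@]1(C)O[C@@H]1C2=O` in an assay (Oryctolagus cuniculus) for inhibition of platelet-activating factor receptor (Cavia porcellus) (on this read-out higher numbers stand for weaker inhibition and lower numbers for stronger inhibition), gives 410 nM.
Compound 2 `C/C1=C\CC[C@@]2(C)O[C@@H]2C(=O)[C@@H]2CC[C@@H](C)[C@](C)(CC1)[C@H]2COC(=O)N(C)C` in this assay gives 180 nM.

Compound 2 stands lowest of the two numbers, with compound 1 the nearest, as the step of a 2.3-fold lower number from compound 1 to compound 2 (0.36 log units; beyond the scatter) shows. Compound 3 `C/C1=C\CC[C@@]2(C)O[C@@H]2C(=O)[C@@H]2CC[C@@H](C)[C@](C)(CC1)[C@H]2COc1ccon1` differs from compound 2 in one place: 1,2-oxazol-3-yl in place of dimethylcarbamoyl on an oxygen on a saturated carbon. Among the compounds with values here, the only measured step, a 2.3-fold lower number from compound 1 to compound 2 (0.36 log units; beyond the scatter), concerns a different group on a carbonyl carbon and does not bear directly on this change, so no step beyond the scatter is expected in either direction. Compound 3 is therefore estimated at 300 nM, within 100 nM to 900 nM, a step of a 1.7-fold higher number from compound 2 to compound 3 (0.22 log units; within the scatter).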

Compound 3, half-maximal inhibitory concentration: 50 nM
Compound 3: the middle estimate sits 6.0-fold (0.78 log units) above what was measured; measured number below the stated range.
By their numbers in this assay, from the lowest: compound 3; then compound 2; then compound 1.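

In this assay, the oxygen on a saturated carbon does not need a carbonyl-containing group for stronger inhibition. Putting 1,2-oxazol-3-yl in place of dimethylcarbamoyl gives a 3.6-fold lower number from compound 2 to compound 3 (0.56 log units; beyond the scatter), and putting it in place of acetyl gives an 8.2-fold lower number from compound 1 to compound 3 (0.91 log units; beyond the scatter). The entering aromatic ring has the same number of heavy atoms as dimethylcarbamoyl, so this gain does not come with a larger count of heavy atoms. No available evidence speaks to the cause of this gain. The compounds shown leave open whether the gain is specific to this ring or would also appear with a phenyl ring on the same oxygen.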